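The compounds below may be only part of what the source reports. "The series", "measured", "known", "first", "only" and "open" are said of these compounds alone.

In a functional assay on HT-29 cells (Homo sapiens) for antiproliferative activity, read by MTT assay, with a stated time of 48 h (a lower number here means a stronger inhibitor, a higher number a weaker inhibitor), the three measured compounds stand as follows:

compound 1 `O=C(/C=C\Nc1ccc(C(F)(F)F)cc1)c1cn(-c2ccccc2)nc1-c1ccc(Cl)cc1` — a limit, > 50000 nM
compound 2 `O=C(/C=C\Nc1ccc(O)cc1)c1cn(-c2ccccc2)nc1-c1ccc(Cl)cc1` — 2500 nM
compound 3 `COc1cc(-c2nn(-c3ccccc3)cc2C(=O)/C=C\Nc2ccc(C(F)(F)F)cc2)cc(OC)c1OC` — a limit, > 50000 nM

The value given for compound 1 is a limit of the assay, not a number. The same holds for compound 3. Compound 2 differs from compound 1 by hydroxy in place of trifluoromethyl on an aromatic carbon; this change brought an at least 20-fold lower number from compound 1 to compound 2 (1.30 log units; beyond the scatter). Compound 3 differs from compound 1 in its core by 3,4,5-trimethoxyphenyl in place of 4-chlorophenyl on an aromatic carbon; here the step is a step that the two limits leave unreadable from compound 1 to compound 3 because of the limit of > 50000 nM in this assay, at which 2 of the 3 values shown sit.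

Compound 4 `COc1cc(-c2nn(-c3ccccc3)cc2C(=O)/C=C\Nc2ccc(O)cc2)cc(OC)c1OC` has not yet been measured. It differs from compound 3 by hydroxy in place of trifluoromethyl on an aromatic carbon, the same change, at the same kind of place, that turned compound 1 into compound 2. Within the data shown here, since compound 3 starts at a limit, the only guide is the step from compound 1 to compound 2. Compound 4 is therefore expected to give a lower number than compound 3, estimated at 5000 nM, with a range from 1500 nM to 50000 nM, which means an expected step of an at least 10-fold lower number from compound 3 to compound 4 (1.00 log units; beyond the scatter).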

Compound 4, half-maximal inhibitory concentration: 2500 nM
Compound 4: the middle estimate sits 2.0-fold (0.30 log units) above what was measured, and the stated range covers the measured number.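

In this assay, hydroxy in place of trifluoromethyl gave an at least 20-fold lower number from compound 3 to compound 4 (1.30 log units; beyond the scatter), so the change carried over from the core of compound 1 to the core of compound 3 and went the same way on both: the same change on two cores in this assay, an at least 20-fold lower number (1.30 log units; beyond the scatter) from compound 1 to compound 2 and an at least 20-fold lower number (1.30 log units; beyond the scatter) from compound 3 to compound 4; the limit leaves it open whether they differ. On the two cores, compound 2 gives 2500 nM and compound 4 gives 2500 nM, the same printed value, but this pair alone does not show that the hydroxy compounds would match on any further core. Compound 1 and compound 3 each stand at a limit and not at a number, so the full size of each step cannot be read, nor can the step from compound 1 to compound 3, because both starting values sit at that limit: the limit of > 50000 nM in this assay, at which 2 of the 4 values shown sit.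

The compounds shown carry only trifluoromethyl or hydroxy at this place, so it stays open whether a methoxy, an amine or a carboxylic acid there would give a similar result. Going by these compounds, it also stays open whether the change would carry over to a core with a longer chain in place of 4-chlorophenyl or 3,4,5-trimethoxyphenyl.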